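Chalcone-pyrazole series: removal of one methoxy on the carbonyl aryl

The source may report more compounds than this note shows. Statements on the series, on what has been measured and on what is new or still open speak of the compounds shown alone.

Measured compounds:
compound 1 `COc1cc(-c2cc(/C=C/C(=O)c3ccc(N)cc3)[nH]n2)cc(OC)c1OC`: 43%
compound 2 `COc1cc(-c2cc(/C=C/C(=O)c3ccc(Cl)c(Cl)c3)[nH]n2)cc(OC)c1OC`: 101%
compound 3 `COc1ccc(C(=O)/C=C/c2cc(-c3cc(OC)c(OC)c(OC)c3)n[nH]2)cc1OC`: 75%

In a functional assay on K562 cells (Homo sapiens) for cytotoxicity, read by sulforhodamine B assay, with a stated time of 48 h, tested at 1 uM (on this read-out lower numbers stand for a stronger effect and higher numbers for a weaker effect at the one concentration tested), compound 3 stands second highest of the three numbers, with compound 2 nearest a number 26 percentage points lower from compound 2 to compound 3 (beyond the scatter) and compound 1 furthest a number 32 percentage points higher from compound 1 to compound 3 (beyond the scatter). Compound 4 `COc1ccc(C(=O)/C=C/c2cc(-c3cc(OC)c(OC)c(OC)c3)n[nH]2)cc1` differs from compound 3 by hydrogen in place of methoxy on an aromatic carbon. The measured steps all exchange the whole aryl on the carbonyl carbon: a number 58 percentage points higher from compound 1 to compound 2 (beyond the scatter) and a number 32 percentage points higher from compound 1 to compound 3 (beyond the scatter) are large, a number 26 percentage points lower from compound 2 to compound 3 (beyond the scatter) modest. For the measured compounds named here, none removes a single methoxy, so no step bears directly on the change; the measured steps do show that this aryl matters in this assay. A step within the scatter is expected, a number 3 percentage points higher from compound 3 to compound 4 (within the scatter). For compound 4 the estimate is 78%, from 55% to 100%.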

Compound 4, a percentage reported as activity, at one concentration (the size of the read-out at that concentration, not a potency): 89%
The estimate for compound 4 lay 11 percentage points below the measured number; measured number inside the range.
By their numbers in this assay, from the lowest: compound 1; then compound 3; then compound 4; then compound 2.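

In this assay, for the compounds shown here, the change from 3,4-dimethoxyphenyl to 4-methoxyphenyl gives the first reading of a single methoxy on this aryl, and its loss counts: a number 14 percentage points higher from compound 3 to compound 4 (beyond the scatter). The 4-methoxyphenyl aryl still stands apart from both 3,4-dichlorophenyl, a number 12 percentage points lower from compound 2 to compound 4 (beyond the scatter), and the amino-bearing aryl, a number 46 percentage points higher from compound 1 to compound 4 (beyond the scatter). No measured evidence here accounts for these steps. Still open, from the compounds shown here alone, is how a hydroxy group or a fluorine on this aromatic carbon would read in place of the hydrogen, and how an unsubstituted phenyl would compare with 4-methoxyphenyl.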